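The compounds below may be only part of what the source reports. "The series", "measured", "known", "first", "only" and "open" are said of these compounds alone.

Measured so far in a functional assay on A549 cells (Homo sapiens) for cytotoxicity, read by MTT assay, with a stated time of 72 h; on this read-out lower numbers stand for stronger inhibition and higher numbers for weaker inhibition:
compound 1 `CN(C)CCn1cnnc1-c1cc(Oc2ccc(NC(=O)N/N=C/c3cccc(Br)c3)cc2F)ccn1`: 970 nM
compound 2 `CN(C)CCn1cnnc1-c1cc(Oc2ccc(NC(=O)N/N=C/c3ccc(O)cc3)cc2F)ccn1`: 3560 nM

For the measured compounds named here, compound 2 holds the highest of the two numbers; the only neighbour is compound 1, the step being a 3.7-fold higher number from compound 1 to compound 2 (0.56 log units; beyond the scatter). Compound 3 `CN(C)CCn1cnnc1-c1cc(Oc2ccc(NC(=O)N/N=C/c3c(O)ccc4ccccc34)cc2F)ccn1` is not yet measured; it differs from compound 2 by 2-hydroxynaphthalen-1-yl in place of 4-hydroxyphenyl on a carbon with a double bond to nitrogen. Going by the values given here, the single measured step shows that the group on this carbon shifts the number beyond the scatter, but it involves different groups and gives no direction for this change. For compound 3 a modest move toward a lower number is expected, estimated at 2000 nM (range 700 nM to 6000 nM), a step of a 1.8-fold lower number from compound 2 to compound 3 (0.25 log units; within the scatter).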

Compound 3, half-maximal inhibitory concentration: 880 nM
For compound 3 the middle estimate is 2.3-fold (0.36 log units) above the measured one; low and high end bracket the measured number.
By their numbers in this assay, from the lowest: compounds 3 and 1 (each within the scatter of the next); then compound 2.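

In this assay, a hydroxyl-bearing group on the carbon with a double bond to nitrogen can match the bromophenyl result: 2-hydroxynaphthalen-1-yl in place of 4-hydroxyphenyl gives a 4.0-fold lower number from compound 2 to compound 3 (0.61 log units; beyond the scatter). Against 3-bromophenyl, the same group gives a 1.1-fold lower number from compound 1 to compound 3 (0.04 log units; within the scatter), so these two different groups cannot be told apart at this position. No supporting evidence bears on this result. As far as these compounds go, whether the second aromatic ring or the different hydroxyl placement drives the step stays open. From the compounds shown here alone, how a group carrying an amine or a carboxylic acid would read here also stays open.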